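A few compounds are considered here, and "the series" means these few. Any claim that something is new, unique, unknown or untested is made for them only; others in the source may bear on it.

Measured compounds:
compound 1, `Cc1cc(COc2cccc(Cl)c2)nc(-c2ccccn2)n1`: 398 nM
compound 2, `COc1cccc(OCc2cc(C)nc(-c3ccccn3)n2)c1`: 2000 nM
compound 3, `CC(=O)Nc1cccc(OCc2cc(C)nc(-c3ccccn3)n2)c1`: > 39800 nM

In a functional assay on cells for antagonist activity at Free fatty acid receptor 1 (Homo sapiens), read by TR-FRET and inositol phosphate accumulation, with a stated time of 2 h (a lower number here means a stronger inhibitor, a higher number a weaker inhibitor), compound 1 gives 398 nM, the lowest of the two numbers available. The nearest number belongs to compound 2, and a 5.0-fold higher number from compound 1 to compound 2 (0.70 log units; beyond the scatter). Compound 3 does not give a number but only a limit, > 39800 nM, which is the limit of > 39800 nM in this assay, at which 1 of the 3 values shown sits. Measured from the other two, an at least 100-fold higher number from compound 1 to compound 3 (2.00 log units; beyond the scatter) and an at least 19-fold higher number from compound 2 to compound 3 (1.29 log units; beyond the scatter).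

Compound 4, `Cc1cc(COc2ccccc2F)nc(-c2ccccn2)n1`, has not yet been measured. It differs from compound 1 in this way: 2-fluorophenyl in place of 3-chlorophenyl on an oxygen on a saturated carbon. Both measured steps from compound 1 replace the chloro with a group carrying oxygen or nitrogen, and both weakened the compound, the methoxy modestly and the acetamido strongly. Among the compounds with values here, compound 4 keeps a halogen on the ring and swaps chloro for fluoro at another place, a change none of the measured steps mirrors. The expectation is therefore a small step in this assay, if any, tending towards a weaker compound, estimated as a 1.8-fold higher number from compound 1 to compound 4 (0.25 log units; within the scatter). Compound 4 is expected to give about 700 nM, within 200 nM to 2500 nM.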

Compound 4, half-maximal inhibitory concentration: 398 nM
Beside the measured number, compound 4's estimate is 1.8-fold (0.25 log units) above it; low and high end bracket the measured number.
By their numbers in this assay, from the lowest: compounds 1 and 4 (each within the scatter of the next); then compound 2. At a limit, above all of these: compound 3.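

Within the data shown here, exchanging 3-chlorophenyl for 2-fluorophenyl gives no change at the digits printed from compound 1 to compound 4 (within the scatter) in this assay and so provides the first change to this aryl group that does not weaken the compound beyond the scatter. Where the earlier steps replaced the chloro with methoxy or acetamido, this one keeps a halogen on the ring, yet it alters both the halogen and its place at once, so the two changes cannot be told apart. The data shown give no reason why the number holds.

A 2-chlorophenyl or a 3-fluorophenyl group would separate the two changes, and a plain phenyl group would show whether a halogen is needed at all. As far as these compounds go, how an amine or a carboxylic acid on this ring would read also stays open.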